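A Sulfonyl Aryl Swap on a Weakly Active Quinolone

The source may report more compounds than this note shows. Statements on the series, on what has been measured and on what is new or still open speak of the compounds shown alone.

Of the compounds shown here, three sharing one core have been measured in a functional assay on KOPN-8 cells (Homo sapiens) for antiproliferative activity, with a stated time of 72 h; a higher number here means that more compound is needed for the effect, a lower number that less compound is needed. Compound 1 `COc1ccc(-c2cc(=O)c3c(OC)cc(OC)cc3n2C)cc1` gives 30000 nM in this assay, and compound 2 `COc1ccc(-c2[nH]c3cc(OC)cc(OC)c3c(=O)c2I)cc1` gives 49400 nM. For compound 3 `COc1ccc(-c2cc(=O)c3c(OC)cc(OC)cc3n2S(=O)(=O)c2ccc(C)c([N+](=O)[O-])c2)cc1` this assay reports only a limit, > 51700 nM, so no number stands for it. Among the measured compounds shown here, that places compound 3 at the edge of what this assay resolves; as the limit of > 51700 nM in this assay, at which 1 of the 3 values shown sits, shows, it is the one compound of the three sitting there, and the values of compound 1 and compound 2 are the only numbers available for comparison.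

Compound 4 `COc1ccc(-c2cc(=O)c3c(OC)cc(OC)cc3n2S(=O)(=O)c2cc(Cl)cc(Cl)c2O)cc1` carries 3,5-dichloro-2-hydroxyphenyl in place of 4-methyl-3-nitrophenyl on a sulfonyl sulfur. For the measured compounds named here, no step between measured compounds involves the group on the sulfonyl sulfur, so there is no measured precedent for this exchange. With compound 3 already at a limit, the expectation for compound 4 is no step beyond the scatter, and most likely another limit. The estimated step of an at least 1.0-fold lower number from compound 3 to compound 4 (0.01 log units; that floor lies within the scatter) is therefore taken as flat. Compound 4 is expected to give about 50000 nM, within a range from 20000 nM to 150000 nM.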

Compound 4, half-maximal effective concentration: > 37900 nM
Compound 4: a limit, no number (the forecaster's own chance of this, stated with the estimate: 70%); the middle value is on the limit's open side.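

In this assay, compound 4 gives only a limit, > 37900 nM. Among the compounds shown here, compound 3 also gives only a limit, > 51700 nM, so no step between compound 3 and compound 4 can be read. The compounds shown leave open how 3,5-dichloro-2-hydroxyphenyl and 4-methyl-3-nitrophenyl on a sulfonyl sulfur compare.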